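Thiophene in Place of Chlorophenyl on a Sigma Ligand

The compounds below may be only part of what the source reports. "The series", "measured", "known", "first", "only" and "open" are said of these compounds alone.

Compound 2 `Clc1ccc(C2=CCN(CCCCc3ccncc3)CC2)cc1` gives 1.04 nM in an assay (brain, Cavia porcellus) for binding affinity to Sigma non-opioid intracellular receptor 1 (Homo sapiens), read by radioligand binding (on this read-out lower numbers stand for stronger inhibition and higher numbers for weaker inhibition), the lowest of the three numbers measured. Compound 1 `C1=C(c2ccccc2)CCN(CCCCc2ccncc2)C1` gives 2.72 nM in this assay, and compound 3 `C1=C(c2c[nH]c3ccccc23)CCN(CCCCc2ccncc2)C1` gives 10.3 nM. Within the data shown here, the single step between compounds that differ in one place, a 2.6-fold lower number from compound 1 to compound 2 (0.42 log units; beyond the scatter), shows what the chlorine adds. Compound 4 `C1=C(c2cccs2)CCN(CCCCc2ccncc2)C1` carries thiophen-2-yl in place of 4-chlorophenyl on a double-bonded ring carbon. Among the measured compounds shown here, no measured step matches this exchange of one aromatic ring for another; only the chlorine step between compound 1 and compound 2 bears on it, and that step was modest. The new ring is therefore expected to leave compound 4 near compound 1, with a modest rise in the number. Compound 4 is expected to give 3 nM, between 1 nM and 9 nM, an expected step of a 2.9-fold higher number from compound 2 to compound 4 (0.46 log units; beyond the scatter).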

Compound 4, inhibition constant: 2.13 nM
The estimate for compound 4 lay 1.4-fold (0.15 log units) above the measured number; low and high end bracket the measured number.
By their numbers in this assay, from the lowest: compound 2; then compounds 4 and 1 (each within the scatter of the next); then compound 3.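

On the double-bonded ring carbon, a five-membered aromatic ring with a sulfur atom can stand in for 4-chlorophenyl at a modest cost: the exchange gives a 2.0-fold higher number from compound 2 to compound 4 (0.31 log units; beyond the scatter) in this assay. Against the unsubstituted ring, thiophen-2-yl in place of phenyl gives a 1.3-fold lower number from compound 1 to compound 4 (0.11 log units; within the scatter) and so cannot be told apart from phenyl here. No evidence at hand accounts for either step. The compounds shown leave open whether a chlorine on the thiophene ring would give the gain seen on phenyl, and how furan-2-yl or pyridin-2-yl would fare at this position.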